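The compounds below may be only part of what the source reports. "The series", "measured", "known", "first", "only" and "open" are said of these compounds alone.

Compound 3 `COc1ccc([C@H]2CC(=O)N(c3ccncc3)C2)cc1OC1CCCC1` carries a pyridin-4-yl on an amide-type nitrogen in a ring. In a functional assay on HEK293 cells (Homo sapiens) for cytotoxicity (on this read-out lower numbers stand for higher toxicity in this test and higher numbers for lower toxicity in this test), compound 3 gives > 10000 nM, which is a limit and not a number. Compound 1 `COc1ccc([C@H]2CC(=O)N(c3ccc(C)c(N)c3)C2)cc1OC1CCCC1` gives > 10000 nM, also a limit. Compound 2 `COc1ccc([C@H]2CC(=O)N(c3cc(N)cc(F)c3)C2)cc1OC1CCCC1` gives > 10000 nM, again a limit. The picture so far is therefore (the limit of > 10000 nM in this assay, at which 3 of the 3 values shown sit), and compound 3 stands level with its two relatives on that limit.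

Compound 4 `COc1ccc([C@H]2CC(=O)N(c3ccc(S(C)(=O)=O)cc3)C2)cc1OC1CCCC1` has a 4-(methylsulfonyl)phenyl in place of the pyridin-4-yl: 4-(methylsulfonyl)phenyl in place of pyridin-4-yl on an amide-type nitrogen in a ring. Three measured steps change the group at this same place: a step that the two limits leave unreadable from compound 1 to compound 2, a step that the two limits leave unreadable from compound 1 to compound 3 and a step that the two limits leave unreadable from compound 2 to compound 3. None of them has a size that can be read, so they offer no direction for the new change.

Going by a step that the two limits leave unreadable from compound 2 to compound 3 for compound 3, the expected result is a step that the limit leaves unreadable from compound 3 to compound 4, with no shift beyond the scatter and most likely another limit. Compound 4 is estimated at 15000 nM, with an expected range from 6000 nM to 40000 nM.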

Compound 4, half-maximal cytotoxic concentration: > 10000 nM
Compound 4: a limit, no number (the forecaster's own chance of this, stated with the estimate: 90%); the middle value does not contradict the limit.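

In this assay compound 4 gives > 10000 nM, which is a limit and not a number, so its steps from compound 1, compound 2 and compound 3 cannot be read. The compounds shown leave open whether these groups on the amide-type nitrogen differ at all in this assay, and by how much.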